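Removing the (morpholin-4-yl)carbonyl group from compound 3

The source may hold more compounds than are shown below. What is called first, only, known or untested is meant among the compounds shown, and "the series" means these compounds.

Measured so far in a physicochemical assay for lipophilicity, using the shake flask method, in phosphate buffer, measured as octanol-water partition, with a stated time of 24 h, at pH 7.4, tested at 100 uM; on this read-out higher numbers stand for higher lipophilicity and lower numbers for lower lipophilicity:

compound 1 `CCOc1cc(C)c(-c2cccc(COc3ccc(OCC(=O)O)c(F)c3)c2)c(C)c1` gives 3.48
compound 2 `Cc1cc(OCCCS(C)(=O)=O)cc(C)c1-c1cccc(COc2ccc(OCC(=O)O)c(F)c2)c1` gives 1.81
compound 3 `Cc1cc(OCC(=O)N2CCOCC2)cc(C)c1-c1cccc(COc2ccc(OCC(=O)O)c(F)c2)c1` gives "not determined" (no result reported)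

Compound 3 has no number to start from, since its entry reads "not determined" (no result reported) and so it has no place on this scale. Compound 4 `COc1cc(C)c(-c2cccc(COc3ccc(OCC(=O)O)c(F)c3)c2)c(C)c1` comes from compound 3 by a single change, (hydrogen in place of (morpholin-4-yl)carbonyl on a saturated chain carbon bound to an oxygen on an aromatic ring), which is hydrogen in place of (morpholin-4-yl)carbonyl on a saturated chain carbon bound to an oxygen on an aromatic ring. Methoxy thus replaces ((morpholin-4-yl)carbonyl)methoxy.

Going by the values given here, only one measured step touches this side chain. A group added to the chain gave a number 1.67 log units lower from compound 1 to compound 2 (beyond the scatter), a large drop, but that group is not the one leaving here, so the step bears only indirectly. It suggests that this part of the molecule can move the read-out a long way. Stripping the chain down to methoxy is therefore expected to give a large rise from compound 3, although the missing number means the size of that step cannot be stated. The closest guide is compound 1 at 3.48 as it also carries a short, undecorated chain, and compound 4 is expected to land near it, perhaps slightly lower.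

For compound 4 the estimated value is 3.2, with an expected range from 2.8 to 3.6 in this assay for this estimate.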

Compound 4, distribution coefficient: 3.2
Beside the measured number, compound 4's estimate shows no gap at the digits printed, within the range that was stated.
By their numbers in this assay, from the lowest: compound 2; then compounds 4 and 1 (each within the scatter of the next).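

In this assay, replacing 2-(methylsulfonyl)ethyl with hydrogen on a saturated chain carbon bound to an oxygen on an aromatic ring gives a number 1.39 log units higher from compound 2 to compound 4 (beyond the scatter), so compound 2 stands well apart from a second short-chain compound as well as from compound 1. Replacing methyl with hydrogen at that same carbon gives a number 0.28 log units lower from compound 1 to compound 4 (within the scatter), which means that this small change cannot be told apart from repeat scatter on this scale. Among these three compounds, then, the large steps both involve the chain ending in methylsulfonyl, while the two short chains stay together, and any step from compound 3 cannot be read, as it has no number; nothing available here gives a measured reason for the size of these steps.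

Between the short chains and the methylsulfonyl chain, the shown compounds give no sign of how the read-out changes with chain length or end group. A longer plain carbon chain, or an amine or a carboxylic acid at the end of this chain, could fall near compound 4, near compound 2, or somewhere between them.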